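Adding a Methoxy Group to a Fused Amide Series

This account rests on a few compounds, and the source may have more. Where it says the series, first, only, none or still open, it means among the compounds named here.

Three compounds share a fused core carrying an amide, and they were tested in a functional assay on DU-145 cells (Homo sapiens) for cytotoxicity, read by MTT assay, with a stated time of 48 h; a lower number here means a stronger inhibitor, a higher number a weaker inhibitor. Compound 1 `COc1ccc(-c2cc(C(=O)Nc3nc4ccc(Cl)cc4s3)nc3cc(-c4ccccc4)nn23)cc1OC` gives 9330 nM, while compound 2 `COc1cc(-c2cc(C(=O)Nc3nc4ccc(Cl)cc4s3)nc3cc(-c4ccccc4)nn23)cc(OC)c1OC` gives 38900 nM. The change methoxy in place of hydrogen on an aromatic carbon produced a step of a 4.2-fold higher number from compound 1 to compound 2 (0.62 log units; beyond the scatter). Compound 3 `COc1ccc(-c2cc(C(=O)Nc3nc4ccc(OC)cc4s3)nc3cc(-c4ccccc4)nn23)cc1` gives 7580 nM; how its core differs from that of compound 1 is not broken down here. Compound 4 `COc1ccc2nc(NC(=O)c3cc(-c4ccc(OC)c(OC)c4)n4nc(-c5ccccc5)cc4n3)sc2c1` is not yet measured and differs from compound 3 by methoxy in place of hydrogen on an aromatic carbon. This is the same kind of change as that from compound 1 to compound 2, though there the entering methoxy is also meta to a methoxy group, which is absent around the place in compound 3. Because a 4.2-fold higher number from compound 1 to compound 2 (0.62 log units; beyond the scatter) weakened the inhibitor, compound 4 is expected to move by an estimated 2.4-fold higher number from compound 3 to compound 4 (0.38 log units; beyond the scatter) in this assay. Compound 4 is therefore estimated at 18000 nM, with a range from 7000 nM to 50000 nM.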

Compound 4, half-maximal inhibitory concentration: 14000 nM
Beside the measured number, compound 4's estimate is 1.3-fold (0.11 log units) above it; measured number inside the range.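

In this assay, the change from 4-methoxyphenyl to 3,4-dimethoxyphenyl gives a 1.8-fold higher number from compound 3 to compound 4 (0.27 log units; within the scatter), and methoxy in place of chloro on the fused core gives a 1.5-fold higher number from compound 1 to compound 4 (0.18 log units; within the scatter). Set beside the earlier methoxy step, the new one does not differ from it: the same change on two cores in this assay, a 4.2-fold higher number (0.62 log units; beyond the scatter) from compound 1 to compound 2 and a 1.8-fold higher number (0.27 log units; within the scatter) from compound 3 to compound 4, 2.3-fold (0.35 log units) apart, within the scatter of two such steps. This fits the methoxy change carrying across these two cores, but it rests on a single pair per core, one step beyond the scatter and one within it, so it does not fix a size for the change across the series.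

As far as these compounds go, it remains open how the change would read on cores carrying an amine or a carboxylic acid in place of the chloro or methoxy group. From the compounds shown here alone, whether an ethoxy group or a longer chain would behave like methoxy is also open.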